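Sulfonamide series at the prostaglandin D2 receptor 2: compound 4

The source may report more compounds than this note shows. Statements on the series, on what has been measured and on what is new or still open speak of the compounds shown alone.

Measured so far:
- compound 1 `Cc1ccc(S(=O)(=O)NC(C)C)cc1C#Cc1cc(Cl)ccc1OCC(=O)O`: 3.4 nM
- compound 2 `CN(c1cccc(C#Cc2cc(Cl)ccc2OCC(=O)O)c1)S(C)(=O)=O`: 122 nM
- compound 3 `CC(C)(C)N1C(=O)c2ccc(C#Cc3cc(Cl)ccc3OCC(=O)O)cc2S1(=O)=O`: 14 nM

In an assay on CHO cells for displacement of a labelled ligand from prostaglandin D2 receptor 2 (Homo sapiens), read by scintillation counting (a lower number here means a stronger inhibitor, a higher number a weaker inhibitor), compound 1 gives 3.4 nM, the lowest number of the three, and its gaps to compound 3 and to compound 2 both lie beyond the scatter, so within this set compound 1 is the most potent. Compound 2, which carries a methylated sulfonamide nitrogen, and compound 3, whose sulfonamide nitrogen sits in a ring, both differ from compound 1 in more than one place, so their weaker values cannot be tied to any single change.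

Compound 4 `Cc1ccc(S(=O)(=O)N2CCCCC2C)cc1C#Cc1cc(Cl)ccc1OCC(=O)O` is not yet measured. It differs from compound 1 only at the sulfonyl group:

2-methylpiperidin-1-yl in place of isopropylamino on a sulfonyl sulfur

For the measured compounds named here, the change removes the hydrogen-bond donor of the sulfonamide and adds a ring, and no measured pair in this assay isolates that change. Compounds 2 and 3, each without that donor, sit above compound 1, so a loss is expected rather than a gain. The expected step of a 2.9-fold higher number from compound 1 to compound 4 (0.47 log units; beyond the scatter) is modest and beyond the scatter. Compound 4 is estimated at 10 nM, with a range of 3 nM to 35 nM in this assay.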

Compound 4, inhibition constant: 1.9 nM
Estimate against measurement, compound 4: 5.3-fold (0.72 log units) above, outside the stated range (below it).
By their numbers in this assay, from the lowest: compounds 4 and 1 (each within the scatter of the next); then compound 3; then compound 2.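

In this assay 2-methylpiperidin-1-yl in place of isopropylamino on a sulfonyl sulfur gives a 1.8-fold lower number from compound 1 to compound 4 (0.25 log units; within the scatter) so this position takes the larger, ring-bearing group without a change beyond the scatter. For the compounds shown here, in this pair the hydrogen-bond donor of the isopropylamino group is therefore not needed to hold a value at this level, which the earlier compounds could not show. No measurement at hand explains this result.

Open, going by these compounds, is what the ring and its methyl each contribute: a plain piperidin-1-yl would separate the two, and a morpholin-4-yl would place an oxygen in the ring. Equally open, on these data alone, is whether a dimethylamino group, which has no ring and no hydrogen on the nitrogen, would sit at the same level.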